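Dropping a fluoro from the central ring of compound 3

The compounds below may be only part of what the source reports. "The series", "measured", "known", "first", "only" and "open" are said of these compounds alone.

In an ADME assay on microsomes from liver (Rattus norvegicus) for metabolic stability (a higher number here means faster removal of the compound, a lower number slower removal), compound 3 `CC(C)COc1ncc(-c2cc(F)c(-c3nnc(S(=O)(=O)C4CCC4)[nH]3)cc2F)cc1Cl` gives 62 uL/min. Compound 1 `CC(C)COc1ncc(-c2cc(F)c(-c3nnc(S(=O)(=O)CC4CC4)[nH]3)cc2F)cc1Cl` gives 58 uL/min in this assay, and compound 2 `COc1cc(-c2nnc(S(=O)(=O)C3CCC3)[nH]2)ccc1-c1cnc(OCC(C)C)c(Cl)c1` gives 61 uL/min; compound 3 sits within the scatter of both, so the three numbers are not separated. For the measured compounds named here, the only single-place step measured, a 1.1-fold higher number from compound 1 to compound 3 (0.03 log units; within the scatter), swaps the group on the sulfonyl sulfur and leaves the aromatic rings untouched.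

Compound 4 `CC(C)COc1ncc(-c2ccc(-c3nnc(S(=O)(=O)C4CCC4)[nH]3)cc2F)cc1Cl` differs from compound 3 by hydrogen in place of fluoro on an aromatic carbon. Going by the values given here, no measured pair isolates this change. Compound 2 and compound 3 differ in more than one place, and their values lie within the scatter of each other, which gives no lever for a shift either way. With nothing in the measured steps pointing to a change beyond the scatter, compound 4 is expected near compound 3, with a 1.0-fold higher number from compound 3 to compound 4 (0.02 log units; within the scatter) as the expected step. Compound 4 is estimated at 65 uL/min, with a range of 35 uL/min to 120 uL/min.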

Compound 4, intrinsic clearance in a liver preparation (reported as CLH), per the amount of preparation that the assay uses: 71 uL/min
The estimate for compound 4 lay 1.1-fold (0.04 log units) below the measured number; the range from low to high includes it.
By their numbers in this assay, from the lowest: compounds 1, 2, 3 and 4 (each within the scatter of the next).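

In this assay, hydrogen in place of fluoro on this aromatic carbon, ortho to a large group and para to a fluoro group, gives a 1.1-fold higher number from compound 3 to compound 4 (0.06 log units; within the scatter) and so leaves the number inside the scatter. On another carbon of the same ring, the remaining fluoro in place of methoxy gives a 1.2-fold higher number from compound 2 to compound 4 (0.07 log units; within the scatter) and likewise stays inside the scatter, so neither single change on this ring separates the values. No available measurement offers an explanation for these small steps.

As far as these compounds go, whether an amine or a carboxylic acid on the carbon that lost its fluoro would produce a step beyond the scatter stays open. Also open, from the compounds shown here alone, is whether hydrogen in place of fluoro behaves the same way with a group other than cyclobutyl on the sulfonyl sulfur.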